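Swapping the Pyridine Ring on a Long-Chain Thiazolidine Amide

The compounds below may be only part of what the source reports. "The series", "measured", "known", "first", "only" and "open" are said of these compounds alone.

Among the measured compounds shown here, compound 1 `CCCCCCCCCCCCCCCCCCNC(=O)[C@H]1CSC(c2cccnc2)N1` gives 7800 nM in a functional assay on TSU-Pr1 cells for antiproliferative activity against TSU (Homo sapiens), read by sulforhodamine B assay (on this read-out higher numbers stand for weaker inhibition and lower numbers for stronger inhibition), the lowest of the two numbers measured so far; compound 2 `CCCCCCCCCCCCCCCCCCNC(=O)[C@H]1CSC(c2ccc([N+](=O)[O-])cc2)N1` gives 15900 nM. Compound 3 `CCCCCCCCCCCCCCCCCCNC(=O)[C@H]1CSC(c2cc(F)cc(F)c2)N1` differs from compound 1 by 3,5-difluorophenyl in place of pyridin-3-yl on a saturated ring carbon. For the measured compounds named here, only one measured step bears on such an exchange of the aromatic group, and it was modest: a 2.0-fold higher number from compound 1 to compound 2 (0.31 log units; beyond the scatter). A step of similar size, or none beyond the scatter, is therefore expected for compound 3, a 1.3-fold higher number from compound 1 to compound 3 (0.11 log units; within the scatter), leaning toward weaker inhibition. Compound 3 is estimated at 10000 nM, within a range from 4000 nM to 25000 nM.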

Compound 3, half-maximal inhibitory concentration: > 20000 nM
Compound 3 was reported as a limit; the forecaster's own chance of this, stated with the estimate: 5%; middle value at least 2.0-fold (0.30 log units) from the limit.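

In this assay, compound 3 gives a limit of the assay rather than a number: the limit of > 20000 nM in this assay, at which 1 of the 3 values shown sits. Even so, the limit is informative, with an at least 2.5-fold higher number from compound 1 to compound 3 (0.40 log units; beyond the scatter), so this position does not accept every aromatic group equally, and both groups without a ring nitrogen give weaker inhibition than pyridin-3-yl. Compounds 2 and 3 cannot be ordered, since an at least 1.2-fold higher number from compound 2 to compound 3 (0.09 log units; that floor lies within the scatter).

On these data alone, it remains open whether the step follows the loss of the ring nitrogen or the arrival of the two fluorines. Plain phenyl, carrying neither, would separate the two.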